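Compound 3 to Compound 4: Expected Cytotoxicity Outcome

A few compounds are considered here, and "the series" means these few. Any claim that something is new, unique, unknown or untested is made for them only; others in the source may bear on it.

In an ADME assay on MRC5 cells (Homo sapiens) for cytotoxicity (on this read-out higher numbers stand for lower toxicity in this test and lower numbers for higher toxicity in this test), compound 3 `Cc1ccc2nc(-c3ccc(NC(=O)NC[C@H]4O[C@H](n5cc(C)c(=O)[nH]c5=O)C[C@@H]4O)cc3)sc2c1` gives > 50000 nM, which is a limit of the assay rather than a number. Compound 1 `Cc1cn([C@@H]2C[C@H](O)[C@@H](CNC(=O)Nc3ccc(Cl)c(C(F)(F)F)c3)O2)c(=O)[nH]c1=O` also reaches only a limit in this assay, > 50000 nM. Compound 2 `Cc1cn([C@@H]2C[C@H](O)[C@@H](CNC(=O)Nc3ccccc3COc3ccccc3)O2)c(=O)[nH]c1=O` likewise stops at a limit, > 50000 nM. Taken together, this means (the limit of > 50000 nM in this assay, at which 3 of the 3 values shown sit). Compound 4 `COc1ccc(COc2ccc(NC(=O)NC[C@H]3O[C@H](n4cc(C)c(=O)[nH]c4=O)C[C@@H]3O)cc2)cc1` has not yet been tested in this assay; it differs from compound 3 by (4-methoxybenzyl)oxy in place of 6-methyl-1,3-benzothiazol-2-yl on an aromatic carbon. Going by the values given here, no step between two measured compounds exists, so the effect of the change cannot be read from a comparison. The step expected here, a step that the limit leaves unreadable from compound 3 to compound 4, is none beyond the scatter. Compound 4 is therefore expected to give about 60000 nM, with a range from 20000 nM to 200000 nM, because the limit of > 50000 nM in this assay, at which 3 of the 3 values shown sit, describes every compound seen so far.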

Compound 4, half-maximal cytotoxic concentration: > 50000 nM
Compound 4: only a limit was reported (the forecaster's own chance of this, stated with the estimate: 85%); the middle value lies beyond the limit too.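

In this assay compound 3 and compound 4 both stop at a limit, and the step between them cannot be read. The compounds shown leave open how far each lies beyond that limit, and whether (4-methoxybenzyl)oxy in place of 6-methyl-1,3-benzothiazol-2-yl changes the read-out at all.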